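This account rests on a few compounds, and the source may have more. Where it says the series, first, only, none or still open, it means among the compounds named here.

Measured compounds:
compound 1 `c1cncc(-c2ccccc2OCC2=NCCN2)c1` — 2 nM
compound 2 `c1cnc(-c2ccccc2OCC2=NCCN2)nc1` — 1260 nM
compound 3 `c1ccc(-c2cnccn2)c(OCC2=NCCN2)c1` — 2.51 nM

Compound 3 gives 2.51 nM in a functional assay for activation of Alpha-1A adrenergic receptor (Homo sapiens), read by calcium flux (on this read-out higher numbers stand for an effect only at larger amounts of compound and lower numbers for an effect already at smaller amounts), the second highest number among the three; the step of a 1.3-fold higher number from compound 1 to compound 3 (0.10 log units; within the scatter) lies within the scatter, while the step of a 500-fold lower number from compound 2 to compound 3 (2.70 log units; beyond the scatter) is large. The next compound, compound 4 `c1ccc(-c2ccncn2)c(OCC2=NCCN2)c1`, has not yet been measured; it differs from compound 3 by pyrimidin-4-yl in place of pyrazin-2-yl on an aromatic carbon.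

Two of the measured steps bear on this change, since they also swap one six-membered heteroaryl ring for another at the same carbon. The step of a 1.3-fold higher number from compound 1 to compound 3 (0.10 log units; within the scatter) was within the scatter, while a 630-fold higher number from compound 1 to compound 2 (2.80 log units; beyond the scatter) and a 500-fold lower number from compound 2 to compound 3 (2.70 log units; beyond the scatter) were large. For the measured compounds named here, only three rings have been tried, so no general rule can be drawn from them: two rings gave low numbers and one gave a high number. Because of the large step of a 500-fold lower number from compound 2 to compound 3 (2.70 log units; beyond the scatter), a rise for compound 4 cannot be ruled out, and the estimate is placed between the two extremes but nearer to the low numbers of compound 1 and compound 3. Compound 4 is therefore expected to give 25 nM, with a range from 3 nM to 300 nM, which would mean an expected step of a 10-fold higher number from compound 3 to compound 4 (1.00 log units; beyond the scatter).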

Compound 4, half-maximal effective concentration: < 100000 nM
Compound 4: a limit, no number (the forecaster's own chance of this, stated with the estimate: 2%); the middle value lies beyond the limit too.
By their numbers in this assay, from the lowest: compounds 1 and 3 (each within the scatter of the next); then compound 2.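

In this assay compound 4 gives < 100000 nM, which is a limit of the assay and not a number. Its steps from compound 1, compound 2 and compound 3 cannot be read. The compounds shown leave open how pyrimidin-4-yl compares with pyridin-3-yl, pyrimidin-2-yl and pyrazin-2-yl at this aromatic carbon.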